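A few compounds are considered here, and "the series" means these few. Any claim that something is new, unique, unknown or untested is made for them only; others in the source may bear on it.

Compound 1, `OCC1CCN(c2nccnc2OC2CN(c3cnc4ccccc4n3)C2)CC1`: 500000 nM
Compound 2, `OCC1CCN(c2nccnc2OC2CN(c3ccc4ccccc4n3)C2)C1`: 167000 nM

Both compounds were measured in a physicochemical assay for solubility, in phosphate buffer, at pH 7.4; a lower number here means a less soluble compound, a higher number a more soluble compound. Within the data shown here, compound 2 gives the lowest of the two numbers, and compound 1, its only neighbour, stands beyond the scatter with the higher number. Compound 3, `N#Cc1ccc(-c2nccnc2OC2CN(c3ccc4ccccc4n3)C2)cc1`, has not yet been measured. (4-cyanophenyl in place of 3-(hydroxymethyl)pyrrolidin-1-yl on an aromatic carbon). For this step, a drop to a clearly lower number in this assay is expected, well beyond the scatter. Compound 3 is estimated at 10000 nM, with a range from 2000 nM to 60000 nM. The expected step is a 17-fold lower number from compound 2 to compound 3 (1.22 log units; beyond the scatter).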

Compound 3, solubility: < 1000 nM
Compound 3 was reported as a limit; the forecaster's own chance of this, stated with the estimate: 15%; middle value at least 10-fold (1.00 log units) away from the limit.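

Putting 4-cyanophenyl in place of 3-(hydroxymethyl)pyrrolidin-1-yl on this aromatic carbon gives, in this assay, an at least 160-fold lower number from compound 2 to compound 3 (2.22 log units; beyond the scatter). Among these compounds, this is the first step that can be read at this position, and it shows that a single change here can move the number by a large amount. Compound 3 stands at a limit, not at a number: the limit of < 1000 nM in this assay, at which 1 of the 3 values shown sits.

Still open, going by these compounds, is which part of the change matters: the loss of the hydroxymethyl, the aromatic ring or the nitrile. A plain phenyl or a morpholine at this position would help separate these.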